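Ortho-fluoro on the aryl ketone of a boron-containing chalcone

This account rests on a few compounds, and the source may have more. Where it says the series, first, only, none or still open, it means among the compounds named here.

Compound 1 `O=C(/C=C/c1ccc2c(c1)B(O)OC2)c1ccccc1`: 2300 nM
Compound 2 `Cn1cccc1C(=O)/C=C/c1ccc2c(c1)B(O)OC2`: > 100000 nM
Compound 3 `O=C(/C=C/c1ccc2c(c1)B(O)OC2)c1ccc(Br)cc1`: 9500 nM

In a functional assay on MDA-MB-231 cells (Homo sapiens) for cytotoxicity, read by MTT assay, with a stated time of 48 h (a higher number here means a weaker inhibitor, a lower number a stronger inhibitor), compound 1 gives the lowest of the two numbers shown, with compound 3 nearest at a 4.1-fold higher number from compound 1 to compound 3 (0.62 log units; beyond the scatter). For compound 2 the assay reports only a limit, (the limit of > 100000 nM in this assay, at which 1 of the 3 values shown sits). Compound 4 `O=C(/C=C/c1ccc2c(c1)B(O)OC2)c1ccccc1F` differs from compound 1 by fluoro in place of hydrogen on an aromatic carbon. Going by the values given here, the only measured step that bears on this change is the one from compound 1 to compound 3, a modest one: a 4.1-fold higher number from compound 1 to compound 3 (0.62 log units; beyond the scatter). A fluoro substituent is expected to move the number less than that, if at all beyond the scatter, so compound 4 is estimated at 3300 nM, between 1400 nM and 8000 nM, a step of a 1.4-fold higher number from compound 1 to compound 4 (0.16 log units; within the scatter).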

Compound 4, half-maximal inhibitory concentration: 2200 nM
Compound 4: the middle estimate sits 1.5-fold (0.18 log units) above what was measured; the measured number falls inside the stated range.
By their numbers in this assay, from the lowest: compounds 4 and 1 (each within the scatter of the next); then compound 3. At a limit, above all of these: compound 2.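

In this assay, the change from phenyl to 2-fluorophenyl gives a 1.0-fold lower number from compound 1 to compound 4 (0.02 log units; within the scatter), so a fluoro ortho to a large group leaves no change that can be read. Replacing 4-bromophenyl with 2-fluorophenyl gives a 4.3-fold lower number from compound 3 to compound 4 (0.64 log units; beyond the scatter), so compound 4 stays level with compound 1, a level that compound 3 does not reach. Replacing 1-methyl-1H-pyrrol-2-yl with 2-fluorophenyl gives an at least 45-fold lower number from compound 2 to compound 4 (1.65 log units; beyond the scatter), a step read against a limit: the limit of > 100000 nM in this assay, at which 1 of the 4 values shown sits.

From the compounds shown here alone, whether a methoxy or an amine at this position would keep the number level stays open. So does how a bromo would read here.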